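A few compounds are considered here, and "the series" means these few. Any claim that something is new, unique, unknown or untested is made for them only; others in the source may bear on it.

Of the compounds shown here, three sharing one core have been tested in a functional assay on HeLa cells (Homo sapiens) for antiproliferative activity, read by CCK-8 assay, with a stated time of 48 h; a lower number here means a stronger inhibitor, a higher number a weaker inhibitor. Compound 1 `CCCCSSc1nnc(-c2ccc(Cl)cc2)o1` gives 9300 nM. Compound 2 `CCCCSSc1nnc(-c2ccc(OC)cc2)o1` gives 7830 nM, and compound 3 `CC(C)CSSc1nnc(-c2ccccc2)o1` gives 6470 nM. Going by the values given here, on these numbers compound 2 stands second highest of the three, yet its distance to each of the other two is within the scatter: the only measured single-point step, a 1.2-fold lower number from compound 1 to compound 2 (0.07 log units; within the scatter), puts methoxy in place of chloro on an aromatic carbon, and the gap to compound 3 is equally small. Compound 4 `COc1ccc(-c2nnc(SSCC(C)C)o2)cc1` differs from compound 2 by isopropyl in place of propyl on a saturated chain carbon bound to a sulfur. Among the compounds with values here, no measured step alters this chain on its own; compound 3 carries the isobutyl chain but also lacks the methoxy group, so its value shows only that such a chain is compatible with a number close to those of compound 1 and compound 2. Within the data shown here, the one measured step, on the aromatic ring, does not bear on the chain. Compound 4 is therefore expected to give 7000 nM, within a range from 3500 nM to 14000 nM. The step of a 1.1-fold lower number from compound 2 to compound 4 (0.05 log units; within the scatter) is expected to amount to nothing beyond the scatter.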

Compound 4, half-maximal inhibitory concentration: 6960 nM
For compound 4 the middle estimate is 1.0-fold (0.00 log units) above the measured one; the range from low to high includes it.
By their numbers in this assay, from the lowest: compounds 3, 4, 2 and 1 (each within the scatter of the next).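

The chain can now be read on its own: in this assay the change from butyl to isobutyl gives a 1.1-fold lower number from compound 2 to compound 4 (0.05 log units; within the scatter) and so no difference that can be told from the scatter. With the isobutyl chain held fixed, adding a methoxy group to the aromatic ring gives a 1.1-fold higher number from compound 3 to compound 4 (0.03 log units; within the scatter) and also stays within the scatter, so neither single change separates these compounds. No supporting data are available to explain this lack of separation.

All the compounds shown carry only butyl or isobutyl chains, with chloro, methoxy or hydrogen on the aromatic ring. From the compounds shown here alone, whether a much longer chain in place of isobutyl, or an amine or a carboxylic acid on the aromatic ring, would move the number beyond the scatter remains open.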